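The source may hold more compounds than are shown below. What is called first, only, known or untested is meant among the compounds shown, and "the series" means these compounds.

Measured so far in a functional assay on Venous blood for antagonist activity at C-X-C chemokine receptor type 3 (Homo sapiens), read by flow cytometry, with a stated time of 30 min, in the presence of a further agent that is not named here; a lower number here means a stronger inhibitor, a higher number a weaker inhibitor:
compound 1 `C[C@@H]1CN(c2sc(C(F)(F)F)nc2-c2nc3ccccc3[nH]2)CCN1C(=O)Cn1cc(Cl)cn1` gives 251 nM
compound 2 `Cc1nc(C)n(CC(=O)N2CCN(c3sc(C(F)(F)F)nc3-c3nc4ccc(OC5CNC5)cc4[nH]3)C[C@H]2C)n1` gives 580 nM
compound 3 `C[C@@H]1CN(c2sc(C(F)(F)F)nc2-c2nc3ccccc3[nH]2)CCN1C(=O)Cn1cc(C2CCN(C)CC2)cn1` gives 1690 nM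

Compound 3 thus stands highest of the three in this assay, with compound 2 closer to it and compound 1 furthest below. Compound 4 `Cc1nc(C)n(CC(=O)N2CCN(c3sc(C(F)(F)F)nc3-c3nc4ccccc4[nH]3)C[C@H]2C)n1` has not been measured; it differs from compound 3 by 3,5-dimethyl-1H-1,2,4-triazol-1-yl in place of 4-(1-methylpiperidin-4-yl)-1H-pyrazol-1-yl on a saturated chain carbon bound to a carbonyl carbon. Within the data shown here, one measured step bears on this: a 6.7-fold higher number from compound 1 to compound 3 (0.83 log units; beyond the scatter). The leaving group therefore came with a clearly higher number, and taking it out is expected to bring the number back down. Among the measured compounds shown here, the entering group has no direct measured counterpart on the shared core; compound 2 carries it, but on a core that also differs elsewhere, so its value is only a loose guide. The expected step is a 4.8-fold lower number from compound 3 to compound 4 (0.68 log units; beyond the scatter). Compound 4 is estimated at 350 nM, expected to fall between 150 nM and 800 nM.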

Compound 4, half-maximal inhibitory concentration: 237 nM
The estimate for compound 4 lay 1.5-fold (0.17 log units) above the measured number; measured number inside the range.
By their numbers in this assay, from the lowest: compounds 4 and 1 (each within the scatter of the next); then compound 2; then compound 3.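

Replacing 4-(1-methylpiperidin-4-yl)-1H-pyrazol-1-yl with 3,5-dimethyl-1H-1,2,4-triazol-1-yl gives a 7.1-fold lower number from compound 3 to compound 4 (0.85 log units; beyond the scatter) and so recovers the lower range, while a 1.1-fold lower number from compound 1 to compound 4 (0.02 log units; within the scatter) shows that this triazolyl group and 4-chloro-1H-pyrazol-1-yl cannot be told apart at this place. Taking off the (azetidin-3-yl)oxy group gives a 2.4-fold lower number from compound 2 to compound 4 (0.39 log units; beyond the scatter) and shows that this group is not needed to reach the lower number. Nothing measured here accounts for these steps. Going by these compounds, whether an open-chain amine or a carboxylic acid would be tolerated at this place remains open.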